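This account rests on a few compounds, and the source may have more. Where it says the series, first, only, none or still open, it means among the compounds named here.

Compound 1 `CN(C)c1ncnc2c1c(-c1ccoc1)cn2[C@@H]1O[C@H](CO)[C@@H](O)[C@H]1O` in an ADME assay on BJ cells (Homo sapiens), read by MTT assay, with a stated time of 72 h (on this read-out lower numbers stand for stronger inhibition and higher numbers for weaker inhibition), gives 99200 nM.
Compound 2 `CN(C)c1ncnc2c1c(-c1cccs1)cn2[C@@H]1O[C@H](CO)[C@@H](O)[C@H]1O` in this assay gives > 100000 nM, which is a limit of the assay rather than a number.

Among the two values shown, compound 1 holds the only actual number; the other entry is a limit. For the measured compounds named here, the one measured step exchanges the furan-3-yl group on an aromatic carbon for thiophen-2-yl, and it reads a number no lower from compound 1 to compound 2 (the limit leaves the size open); its size stays open because the limit of > 100000 nM in this assay, at which 1 of the 2 values shown sits, caps what the assay can report. Compound 3 `CNc1ncnc2c1c(-c1ccoc1)cn2[C@@H]1O[C@H](CO)[C@@H](O)[C@H]1O` is not yet measured. It differs from compound 1 as follows: hydrogen in place of methyl on a nitrogen on an aromatic ring. Going by the values given here, no measured step touches the dimethylamino group, so the single measured step offers no direct guide to this change; what it does show is that compound 1 sits close to the upper end of what this assay can report. The step from compound 1 to compound 3 is therefore expected to be small, within the usual scatter, and the estimate reads a 1.0-fold higher number from compound 1 to compound 3 (0.00 log units; within the scatter). Compound 3 is estimated at 100000 nM, with a range from 40000 nM to 250000 nM.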

Compound 3, half-maximal inhibitory concentration: 96300 nM
For compound 3 the middle estimate is 1.0-fold (0.02 log units) above the measured one; the measured number falls inside the stated range.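

Exchanging one methyl for hydrogen turns the dimethylamino group into methylamino, and this is the first change shown at this nitrogen. In this assay the step reads a 1.0-fold lower number from compound 1 to compound 3 (0.01 log units; within the scatter). With the furan-3-yl group and the rest of the core unchanged, this one methyl therefore makes no difference that can be told apart from the ordinary spread of repeat measurements, though the test is a weak one, as compound 2 stands at a limit of the assay, not a number, and the readings of the other two compounds lie close to it: the limit of > 100000 nM in this assay, at which 1 of the 3 values shown sits.

The compounds shown leave open whether a larger change on this nitrogen, such as a free amino group, a longer chain as in diethylamino, or a morpholine ring, would give a clearly different reading, and in particular a much lower one. It is also open whether the methylamino group would read the same alongside thiophen-2-yl, since the two changes are not shown together in one compound.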